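A Second Methoxy Group in a Whole-Animal Inhibition Series

A few compounds are considered here, and "the series" means these few. Any claim that something is new, unique, unknown or untested is made for them only; others in the source may bear on it.

Compound 1, `COc1ccc(-c2ncc(C(=O)O)c(=O)[nH]2)cc1`, in a functional assay on the whole organism (strain Sprague-Dawley) for inhibition, with Rattus norvegicus as the target, with a stated time of 10 min (a higher number here means that more compound is needed for the effect, a lower number that less compound is needed), gives > 5 mg/kg, which is a limit of the assay and not a number.
Compound 2, `COc1ccc(-c2ncc(C(=O)O)c(=O)[nH]2)c(OC)c1`, gives 5 mg/kg in this assay.
Compound 3, `CCOC(=O)c1cnc(-c2ccccc2OC)[nH]c1=O`, gives 10 mg/kg in this assay.

Compound 1 and compound 2 differ in one place only: methoxy in place of hydrogen on an aromatic carbon. This change gave a number no higher from compound 1 to compound 2 (the limit leaves the size open). The size of that step cannot be read, since compound 1 sits at the limit of > 5 mg/kg in this assay, at which 1 of the 3 values shown sits. The difference between the core of compound 1 and the core of compound 3 is not broken down here. The gap between compound 3 and compound 2 in this assay lies within the usual scatter of this kind of measurement.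

Compound 4, `CCOC(=O)c1cnc(-c2cc(OC)ccc2OC)[nH]c1=O`, has not yet been measured. It differs from compound 3 by methoxy in place of hydrogen on an aromatic carbon. Within the data shown here, this is the same kind of change as the one from compound 1 to compound 2, but not the same: there the new group sat ortho to a large group and meta to a methoxy group, here it sits meta to a large group and para to a methoxy group.

In this assay compound 4 is expected to give about 7 mg/kg, with a likely range from 3 mg/kg to 20 mg/kg. This expectation rests on compound 3 with its value 10 mg/kg and on compound 1 and compound 2, whose step a number no higher from compound 1 to compound 2 (the limit leaves the size open) is open in size. The expected step is therefore a 1.4-fold lower number from compound 3 to compound 4 (0.15 log units; within the scatter).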

Compound 4, dose for 50% inhibition: 5 mg/kg
Compound 4: middle estimate off by 1.4-fold (0.15 log units), on the high side; low and high end bracket the measured number.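

In this assay, methoxy in place of hydrogen on the aromatic ring gives a 2.0-fold lower number from compound 3 to compound 4 (0.30 log units; within the scatter), which means that on this core the effect of the change cannot be told apart from the ordinary spread of repeated measurements. Comparing this result with the same kind of change on the other core settles little: the same change on two cores in this assay, a number no higher (the limit leaves the size open) from compound 1 to compound 2 and a 2.0-fold lower number (0.30 log units; within the scatter) from compound 3 to compound 4; the limit leaves it open whether they differ Compound 1 gives > 5 mg/kg, which is a limit and not a number, and the step that starts from it cannot be read, so these compounds neither show that the change carries over from one core to the other with the same size nor show that it fails to do so: the limit of > 5 mg/kg in this assay, at which 1 of the 4 values shown sits.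

Among these compounds, the only group added to the aromatic ring in these comparisons is methoxy, and it remains open whether an amine, a fluorine atom or a longer chain in the same place would shift the dose by more than the usual scatter. As far as these compounds go, it also remains open how the methoxy step would read on the core of compound 1 if that core gave a true number, and whether a third core would behave like either of these two.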